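The source may hold more compounds than are shown below. What is called first, only, known or untested is meant among the compounds shown, and "the series" means these compounds.

Three compounds have been measured in a functional assay on M21 cells (Homo sapiens) for antiproliferative activity, read by sulforhodamine B assay, with a stated time of 48 h; a higher number here means a weaker inhibitor of growth, a lower number a stronger inhibitor of growth:

Compound 1, `COc1ccc(-c2cc(N3CCC(CNS(N)(=O)=O)CC3)ncn2)cc1`, gives > 100000 nM, which is a limit of the assay and not a number.
Compound 2, `NS(=O)(=O)NCC1CCN(c2cc(-c3ccc(Cl)cc3)ncn2)CC1`, gives 50300 nM.
Compound 3, `COc1ccc(-c2cc(N3CCC(CCNS(N)(=O)=O)CC3)ncn2)cc1`, gives 69800 nM.

Compound 4, `NS(=O)(=O)NCCC1CCN(c2cc(-c3ccc(Cl)cc3)ncn2)CC1`, has not yet been measured in this assay. It differs from compound 3 by chloro in place of methoxy on an aromatic carbon. The same change has already been made once, from compound 1 to compound 2, where it reads (chloro in place of methoxy on an aromatic carbon); that step gave an at least 1.9-fold lower number from compound 1 to compound 2 (0.29 log units; that floor lies within the scatter). Its size rests on (the limit of > 100000 nM in this assay, at which 1 of the 3 values shown sits), so only a floor for the step is known, and that floor lies within the scatter.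

The two cores on which the change is made differ as well: compound 3 differs from compound 1 by (sulfamoylamino)methyl in place of sulfamoylamino on a saturated chain carbon bound to a saturated ring carbon, a step of an at least 1.4-fold lower number from compound 1 to compound 3 (0.15 log units; that floor lies within the scatter), again resting on a limit. Compound 3 and compound 2 sit within the scatter of each other, so nothing can be said about which inhibits growth more strongly.

For compound 4 the expected step from compound 3 is a 1.7-fold lower number from compound 3 to compound 4 (0.24 log units; within the scatter), which rests on the earlier step of an at least 1.9-fold lower number from compound 1 to compound 2 (0.29 log units; that floor lies within the scatter) having moved the number at least somewhat downward and on the change being the same one at the same place. With the floor of that earlier step within the scatter, the estimate for compound 4 is 40000 nM, expected to fall between 15000 nM and 100000 nM.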

Compound 4, concentration for 50% growth inhibition: 45200 nM
Compound 4: middle estimate off by 1.1-fold (0.05 log units), on the low side; the measured number falls inside the stated range.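

In this assay, going from 4-methoxyphenyl to 4-chlorophenyl gives a 1.5-fold lower number from compound 3 to compound 4 (0.19 log units; within the scatter), so on this core the change shows no real shift, and it can be set beside the earlier case: the same change on two cores in this assay, an at least 1.9-fold lower number (0.29 log units; that floor lies within the scatter) from compound 1 to compound 2 and a 1.5-fold lower number (0.19 log units; within the scatter) from compound 3 to compound 4; the limit leaves it open whether they differ. The other change, (sulfamoylamino)methyl in place of sulfamoylamino, gives a 1.1-fold lower number from compound 2 to compound 4 (0.05 log units; within the scatter), which is also too small to count on the chloro compounds, and it too has an earlier case: the same change on two cores in this assay, an at least 1.4-fold lower number (0.15 log units; that floor lies within the scatter) from compound 1 to compound 3 and a 1.1-fold lower number (0.05 log units; within the scatter) from compound 2 to compound 4; the limit leaves it open whether they differ. Among the compounds shown here, compound 1 stands at a limit of the assay and not at a number, so the earlier steps have only floors, and the series cannot show whether either change keeps its size from one core to the other: the limit of > 100000 nM in this assay, at which 1 of the 4 values shown sits.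

From the compounds shown here alone, only methoxy and chloro appear on the aromatic ring here, so it stays open how a nitrile, a fluoro group or an amine in that place would read. All four compounds also end in the sulfamoylamino group, which leaves open whether a carboxylic acid there, or a longer chain, would move the number beyond the scatter.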